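This account rests on a few compounds, and the source may have more. Where it says the series, first, only, none or still open, it means among the compounds named here.

The shared core appears in compound 1 `CC1(C)Cc2c(ccc(C(=O)/C=C/c3cn(-c4ccccc4)nc3-c3ccc([N+](=O)[O-])cc3)c2OCc2ccccc2)O1`, compound 2 `CC1(C)Cc2c(ccc(C(=O)/C=C/c3ccc(Br)cc3)c2OCc2ccccc2)O1` and compound 3 `Cc1ccc(-c2nn(-c3ccccc3)cc2/C=C/C(=O)c2ccc3c(c2OCc2ccccc2)CC(C)(C)O3)cc1`. In a functional assay on PC-3 cells (Homo sapiens) for antiproliferative activity, read by MTT assay, with a stated time of 48 h (on this read-out lower numbers stand for stronger inhibition and higher numbers for weaker inhibition), compound 1 gives 62300 nM. In this assay compound 3 gives 24200 nM, which makes a 2.6-fold lower number from compound 1 to compound 3 (0.41 log units; beyond the scatter). For compound 2 this assay reports no number but only the limit of > 50000 nM. Compound 2 therefore stands at the limit of > 50000 nM in this assay, at which 1 of the 3 values shown sits. Compound 4 `COc1ccc(/C=C/C(=O)c2ccc3c(c2OCc2ccccc2)CC(C)(C)O3)cc1` differs from compound 2 by methoxy in place of bromo on an aromatic carbon. Going by the values given here, no measured step covers methoxy in place of bromo; the one measured step concerns nitro and methyl on a different part of the molecule, so no step beyond the scatter is expected from compound 2 to compound 4, and a limit may be returned again. Compound 4 is estimated at 60000 nM, with a range from 20000 nM to 200000 nM. The expected step is a step that the limit leaves unreadable from compound 2 to compound 4.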

Compound 4, half-maximal inhibitory concentration: 48900 nM
For compound 4 the middle estimate is 1.2-fold (0.09 log units) above the measured one; measured number inside the range.
By their numbers in this assay, from the lowest: compound 3; then compounds 4 and 1 (each within the scatter of the next).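

With 4-methoxyphenyl in place of 4-bromophenyl, this position, para to a large group, now yields a readable number: in this assay compound 4 gives 48900 nM and not a limit. Compound 2 has in this assay only a limit, > 50000 nM and no number. On these data alone, the change can therefore be read only as an at least 1.0-fold lower number from compound 2 to compound 4 (0.00 log units; that floor lies within the scatter) and its true size stays unknown, since it rests on that limit: the limit of > 50000 nM in this assay, at which 1 of the 4 values shown sits.

Among the compounds that differ only at this position, just bromo and methoxy are shown. As far as these compounds go, how an amine or a carboxylic acid there would read remains open.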